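This account rests on a few compounds, and the source may have more. Where it says the series, first, only, none or still open, it means among the compounds named here.

Measured compounds:
- compound 1, `COc1cc(-c2nc(N(C)C)sc2-c2ccc3ccccc3c2)cc(OC)c1OC`: 729 nM in a functional assay on HT-29 cells (Homo sapiens) for antiproliferative activity, read by MTT assay, with a stated time of 72 h; a higher number here means a weaker inhibitor, a lower number a stronger inhibitor
- compound 2, `COc1ccc(-c2sc(N(C)C)nc2-c2cc(OC)c(OC)c(OC)c2)cc1`: 497 nM in this assay

Compound 2 stands at the lowest of the two numbers in this assay; its nearest neighbour is compound 1, and the step of a 1.5-fold lower number from compound 1 to compound 2 (0.17 log units; within the scatter) is within the scatter, so the two are not separated.

Compound 3, `COc1ccc(-c2sc(C)nc2-c2cc(OC)c(OC)c(OC)c2)cc1`, is not yet measured in this assay. It differs from compound 2 in one place: methyl in place of dimethylamino on an aromatic carbon. Going by the values given here, this is a change at a different position from the one measured step, which exchanged the aryl substituent on the core and left the dimethylamino group in place. Among the compounds with values here, no measured pair alters the group on this ring carbon, so nothing in the data speaks to the size or direction of the effect.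

The expectation for compound 3 therefore rests on the value of compound 2, 497 nM, as the only anchor, with a wide range in both directions. Compound 3 is expected to give about 800 nM in this assay, with a range from 200 nM to 3500 nM, which corresponds to an expected step of a 1.6-fold higher number from compound 2 to compound 3 (0.21 log units; within the scatter) and is not a claim beyond the scatter.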

Compound 3, half-maximal inhibitory concentration: 1420 nM
For compound 3 the middle estimate is 1.8-fold (0.25 log units) below the measured one; the range from low to high includes it.
By their numbers in this assay, from the lowest: compounds 2, 1 and 3 (each within the scatter of the next, the first and the last beyond it).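

In this assay, going by these compounds alone, methyl in place of dimethylamino on this aromatic carbon, next to the ring nitrogen and the ring sulfur, gives a 2.9-fold higher number from compound 2 to compound 3 (0.46 log units; beyond the scatter) and is the first change that separates two compounds. Within the data shown here, the aryl exchange, a 1.5-fold lower number from compound 1 to compound 2 (0.17 log units; within the scatter), did not do so, which makes this ring carbon the one place so far where a single change moves the number beyond the scatter, though only modestly, with dimethylamino on the lower side of the pair. Nothing available accounts for the size or direction of this step.

Still open, as far as these compounds go, is whether the lower number goes with the nitrogen on this carbon or with the larger group, a question that an amino or methylamino group and an isopropyl group at the same place could help to separate. Also open, from the compounds shown here alone, is whether the step keeps its direction and size when naphthalen-2-yl, as in compound 1, stands in place of 4-methoxyphenyl on the shared core.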